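Shortening the Alkyl Chain on the Sulfonyl Aryl Ring

The source may report more compounds than this note shows. Statements on the series, on what has been measured and on what is new or still open speak of the compounds shown alone.

Compound 1 `C#Cc1ccc(S(=O)(=O)Nc2cccc(-c3csc(NC(C)=O)n3)c2)cc1`: 1.2%
Compound 2 `CCCCCC/C=C\c1ccc(S(=O)(=O)Nc2cccc(-c3csc(NC(C)=O)n3)c2)cc1`: <= 1%

In a functional assay on A-375 cells (Homo sapiens) for antiproliferative activity, read by trypan blue exclusion, with a stated time of 48 h, tested at 10 uM (on this read-out lower numbers stand for a stronger effect and higher numbers for a weaker effect at the one concentration tested), compound 1 gives 1.2%. Compound 2 reaches a limit of the assay at <= 1%, and (the limit of <= 1% in this assay, at which 1 of the 2 values shown sits). For the measured compounds named here, the only measured step, a number at least 0.2 percentage points lower from compound 1 to compound 2 (that floor lies within the scatter), therefore says little beyond placing both compounds at or near the floor. Compound 3 `CCCCCCc1ccc(S(=O)(=O)Nc2cccc(-c3csc(NC(C)=O)n3)c2)cc1` differs from compound 2 by a group of 6 heavy atoms (6 carbon; no ring) in place of a group of 8 heavy atoms (8 carbon; no ring), on an aromatic carbon. Going by the values given here, with compound 2 standing at a limit, no measured step bears directly on this change, so compound 3 is expected to stay near the floor as well: the estimate is 1.5%, ranging from 0.5% to 8%. The expected step is a number at least 0.5 percentage points higher from compound 2 to compound 3 (that floor lies within the scatter), within the scatter.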

Compound 3, a percentage reported as activity, at one concentration (the size of the read-out at that concentration, not a potency): <= 1%
Compound 3: a limit, no number; the forecaster's own chance of this, stated with the estimate: 40%; middle value at least 0.5 percentage points from the limit.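

In this assay, compound 3 stands at a limit, as compound 2 does, so a hexyl group without a double bond at this position also reaches the floor of the read-out. Hexyl in place of ethynyl gives a number at least 0.2 percentage points lower from compound 1 to compound 3 (that floor lies within the scatter), while the step between the two limits cannot be read. Chain length at this position therefore cannot be ranked from these compounds: the limit of <= 1% in this assay, at which 2 of the 3 values shown sit.

Still open, going by these compounds, is whether a chain shorter than hexyl, such as methyl or ethyl, would also reach this limit. An amine or a carboxylic acid at this position remains an open case too.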